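The compounds below may be only part of what the source reports. "The series", "measured", "known", "first", "only" and "open" are said of these compounds alone.

Compound 2 `O=C1C(Nc2ccc(F)cc2)=CC(=O)c2ncncc21` gives 0.04 ug/mL in a functional assay on XF498 cells (Homo sapiens) for cytotoxicity, read by MTT assay, with a stated time of 72 h (on this read-out lower numbers stand for stronger inhibition and higher numbers for weaker inhibition), the higher of the two numbers in hand, and its nearest neighbour is compound 1 `CCOc1ccc(NC2=CC(=O)c3ncncc3C2=O)cc1`, which gives 0.03 ug/mL. For the measured compounds named here, the one step measured so far, a 1.3-fold higher number from compound 1 to compound 2 (0.12 log units; within the scatter), shows that a swap at this position leaves the number inside the scatter. Compound 3 `O=C1C(Nc2ccccc2)=CC(=O)c2ncncc21` differs from compound 2 by hydrogen in place of fluoro on an aromatic carbon. Going by the values given here, since the one comparable step left the read-out essentially unchanged, the step of no change at the digits printed from compound 2 to compound 3 (within the scatter) is expected to stay within the scatter as well. Compound 3 is therefore estimated at 0.04 ug/mL, within a range of 0.015 ug/mL to 0.1 ug/mL.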

Compound 3, half-maximal inhibitory concentration: 0.01 ug/mL
The estimate for compound 3 lay 4.0-fold (0.60 log units) above the measured number; the measured number lies below the stated range.
By their numbers in this assay, from the lowest: compound 3; then compounds 1 and 2 (each within the scatter of the next).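

In this assay, hydrogen on this aromatic carbon, para to a large group, moves the number beyond the scatter from either substituted compound: a 4.0-fold lower number from compound 2 to compound 3 (0.60 log units; beyond the scatter), and a 3.0-fold lower number from compound 1 to compound 3 (0.48 log units; beyond the scatter). The position therefore does respond to change, even though fluoro and ethoxy stay within the scatter of each other, and the divide so far lies between hydrogen and these two groups. No evidence is available to explain this difference. On these data alone, whether an amine, a carboxylic acid or a chloro group here would fall with hydrogen or with fluoro and ethoxy remains open.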